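The source may hold more compounds than are shown below. What is called first, only, known or untested is meant among the compounds shown, and "the series" means these compounds.

Measured so far in a functional assay on cells (Cancer cell lines, Homo sapiens) for inhibition; a lower number here means a stronger inhibitor of growth, a higher number a weaker inhibitor of growth
- compound 1 `Cc1cc(-c2nc3sc(C)cn3c2/C=N/NC(=N)N)c(C)s1` gives 8320 nM
- compound 2 `N=C(N)N/N=C/c1c(-c2cc(Cl)sc2Cl)nc2n1CCS2` gives 8710 nM

Not yet measured
- compound 3 `Cc1cc(-c2nc3sccn3c2/C=N/NC(=N)N)c(C)s1`

Within the data shown here, compound 1 and compound 2 lie within the scatter of each other, so compound 1 cannot be ranked against the only other measured compound. Compound 3 differs from compound 1 in one place (hydrogen in place of methyl on an aromatic carbon), with hydrogen in place of methyl on an aromatic carbon. This carbon is on a five-membered aromatic ring with 1 nitrogen and 1 sulfur, part of a fused or bridged system of two rings, next to the ring sulfur.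

Among the measured compounds shown here, no measured pair differs in one place only, so the series gives no direct guide to this change and no firm direction. The expectation therefore rests on compound 1 at 8320 nM in this assay, and no step beyond the scatter is expected. The estimated change is a 1.0-fold lower number from compound 1 to compound 3 (0.02 log units; within the scatter), with the direction left open. For the measured compounds named here, for compound 3 the expected value is 8000 nM, with an estimated range from 3000 nM to 20000 nM, kept wide since only two values are available.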

Compound 3, concentration for 50% growth inhibition: 15500 nM
The estimate for compound 3 lay 1.9-fold (0.29 log units) below the measured number; the measured number falls inside the stated range.
By their numbers in this assay, from the lowest: compounds 1, 2 and 3 (each within the scatter of the next).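

In this assay, among these compounds, compound 1 and compound 3 form the first pair that differs in one place only, methyl against hydrogen on an aromatic carbon next to the ring sulfur, and the pair reads a 1.9-fold higher number from compound 1 to compound 3 (0.27 log units; within the scatter). This step lies within the scatter, so neither group can be ranked over the other at this position, and this single pair gives no sign that the methyl is needed for growth inhibition in these cells. Nothing measured on these compounds speaks to what lies behind this reading.

The compounds shown leave open whether a different group on this carbon, such as a chlorine atom, an ethyl chain, an amine or a carboxylic acid, would give a step beyond the scatter, since only methyl and hydrogen are compared here. Among the compounds shown here, they also leave open whether the same reading would hold with another substituent pattern on the thiophene-bearing side of the molecule, as the single pair was read with that part held constant.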